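This account rests on a few compounds, and the source may have more. Where it says the series, first, only, none or still open, it means among the compounds named here.

Measured in an ADME assay on MRC5 cells (Homo sapiens) for inhibition, with a stated time of 72 h; a higher number here means that more compound is needed for the effect, a lower number that less compound is needed:
- compound 1 `COc1cccc(OC)c1C(=O)Nc1c[nH]nc1C(=O)NCc1ccccn1`: > 50000 nM, a limit
- compound 2 `COc1cccc(OC)c1C(=O)Nc1c[nH]nc1C(=O)NCc1ccccc1`: 50000 nM
- compound 3 `COc1cccc(OC)c1C(=O)Nc1c[nH]nc1C(=O)NCCCOC(C)C`: > 50000 nM, a limit

Compound 3 stands on (the limit of > 50000 nM in this assay, at which 2 of the 3 values shown sit). Compound 4 `COc1cccc(OC)c1C(=O)Nc1c[nH]nc1C(=O)NC1CCCCC1` carries cyclohexyl in place of 3-isopropoxypropyl on an amide-type nitrogen. The measured steps on this same amide substituent give no size: a number no higher from compound 1 to compound 2 (the limit leaves the size open), a step that the two limits leave unreadable from compound 1 to compound 3 and a number no lower from compound 2 to compound 3 (the limit leaves the size open). Among the measured compounds shown here, compound 2 is the only one with a number, 50000 nM, and it anchors the expectation. No change beyond the scatter is expected in this assay, so the estimate is an at least 1.2-fold lower number from compound 3 to compound 4 (0.09 log units; that floor lies within the scatter). For compound 4 the expected value is 40000 nM, with an estimated range of 15000 nM to 50000 nM.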

Compound 4, half-maximal effective concentration: 35000 nM
Compound 4: the middle estimate sits 1.1-fold (0.06 log units) above what was measured; measured number inside the range.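

In this assay, among the compounds shown here, cyclohexyl on the amide-type nitrogen gives a second readable number at this position, where the earlier steps gave no size. The comparison with benzyl is a 1.4-fold lower number from compound 2 to compound 4 (0.15 log units; within the scatter), so these two substituents are not separated. The steps from the two limits are an at least 1.4-fold lower number from compound 3 to compound 4 (0.15 log units; that floor lies within the scatter) and an at least 1.4-fold lower number from compound 1 to compound 4 (0.15 log units; that floor lies within the scatter), so no change beyond the scatter is shown at this position: the limit of > 50000 nM in this assay, at which 2 of the 4 values shown sit.

Still open, going by these compounds, is whether a piperidine or a carboxylic acid on this nitrogen would move the number beyond the scatter. The rest of the shared core is the same in all compounds shown, so its contribution cannot be read.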